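A few compounds are considered here, and "the series" means these few. Any claim that something is new, unique, unknown or untested is made for them only; others in the source may bear on it.

Compound 1 `COc1ccc([C@@H]2C/C(=N/OCc3cn(-c4ccccc4CO)nn3)c3cc(CC=C(C)C)c(OC)cc3O2)cc1` is one of three compounds sharing a core, and in a functional assay on MCF7 cells (Homo sapiens) for inhibition, read by sulforhodamine B assay, with a stated time of 48 h, tested at 50 uM (on this read-out lower numbers stand for less inhibition of growth and higher numbers for more inhibition of growth at the one concentration tested), compound 1 gives 100%, the highest of the three numbers. Compound 2 `COc1cc2c(cc1CC=C(C)C)C(=O)C[C@@H](c1ccc(Oc3cccc([N+](=O)[O-])c3)cc1)O2` gives 53% in this assay, and compound 3 `C#CCOc1ccc([C@@H]2CC(=O)c3cc(CC=C(C)C)c(OC)cc3O2)cc1` gives 68%. Within the data shown here, the one step measured, a number 15 percentage points higher from compound 2 to compound 3 (beyond the scatter), concerns a group on an oxygen on an aromatic ring and not the part of the molecule that changes here. Compound 4 `COc1ccc([C@@H]2C/C(=N/OCc3cn(-c4cccnc4Cl)nn3)c3cc(CC=C(C)C)c(OC)cc3O2)cc1` differs from compound 1 by 2-chloropyridin-3-yl in place of 2-(hydroxymethyl)phenyl on an aromatic nitrogen. Among the measured compounds shown here, no measured step touches that aromatic nitrogen, so the account rests on compound 1 alone, whose value sits at the top of the scale. The step is estimated as a number 10 percentage points lower from compound 1 to compound 4 (within the scatter), and compound 4 is expected to give 90% with a range of 70% to 100%.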

Compound 4, percent growth inhibition at one concentration: 35%
Compound 4: the middle estimate sits 55 percentage points above what was measured; measured number outside the range, below it.
By their numbers in this assay, from the lowest: compound 4; then compound 2; then compound 3; then compound 1.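

In this assay the group on this aromatic nitrogen proves decisive, as 2-chloropyridin-3-yl in place of 2-(hydroxymethyl)phenyl gives a number 65 percentage points lower from compound 1 to compound 4 (beyond the scatter) with the rest of the molecule unchanged. The change removes a hydrogen-bond donor and brings in a ring nitrogen and a chlorine together, so this single step cannot separate them. Nothing available explains the drop.

Which of these differences carries the step remains open. So does how a 2-(aminomethyl)phenyl or 2-carboxyphenyl group on the same nitrogen would read.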